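The source may report more compounds than this note shows. Statements on the series, on what has been measured and on what is new or still open speak of the compounds shown alone.

For the measured compounds named here, in a functional assay on HT-29 cells (Homo sapiens) for inhibition, read by sulforhodamine B assay, with a stated time of 48 h (a higher number here means a weaker inhibitor of growth, a lower number a stronger inhibitor of growth), compound 2 `CC(C)(C)NCc1c(C(=O)O)nn(-c2ccccc2)c1-c1ccc(Cl)cc1` gives 353000 nM, the only exact number so far. Compound 1 `CC(C)(C)NCc1c(C(=O)O)nn(-c2ccccc2)c1-c1ccc(F)cc1` carries fluoro where compound 2 carries chloro. For compound 1 the assay reports only a limit, > 680000 nM.

The next structure, compound 3 `CC(C)(C)NCc1c(C(=O)O)nn(-c2ccccc2)c1-c1ccccc1`, differs from compound 2 by one small edit: hydrogen in place of chloro on an aromatic carbon. Hydrogen stands in place of chloro on an aromatic carbon, which turns 4-chlorophenyl into phenyl.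

Going by the values given here, one measured step bears on this edit, since it also changes only the group at that place: an at least 1.9-fold lower number from compound 1 to compound 2 (0.28 log units; that floor lies within the scatter). Its size is known only as a floor, and that floor lies within the scatter, so this step shows no firm change. It offers little reason to predict a large shift when chloro leaves, although a single step is thin evidence. No step beyond the scatter is therefore expected in this assay, and compound 3 could also be reported only as a limit.

The expected step is a 1.3-fold higher number from compound 2 to compound 3 (0.11 log units; within the scatter). The estimated value for compound 3 is 450000 nM, with an expected range of 200000 nM to 1000000 nM.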

Compound 3, concentration for 50% growth inhibition: > 716000 nM
Compound 3 ended at the assay's limit (the forecaster's own chance of this, stated with the estimate: 35%); at least 1.5-fold (0.20 log units) between middle value and limit.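

Compound 3 has phenyl where compound 2 has 4-chlorophenyl. In this assay compound 3 is reported only as a limit, > 716000 nM. Taking chloro away gives an at least 2.0-fold higher number from compound 2 to compound 3 (0.30 log units; that floor lies within the scatter), so the true size of this step is unknown: it could stay within the scatter or turn out much larger, and the data show no firm change. What is new is that hydrogen, like fluoro, leaves the reading at a limit of the assay, so among these three compounds only compound 2 has an exact number, and the step between the two limits cannot be read.

On these data alone, it remains open whether any group on this aromatic carbon, para to a large group, can bring the number clearly below that of compound 2, and a bromo or a methoxy group there would test this only if it gave an exact value. Also open is how the series would read with a group other than the carboxylic acid on the shared core, such as a primary amide, since all three compounds shown keep that acid unchanged.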